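This account rests on a few compounds, and the source may have more. Where it says the series, first, only, none or still open, it means among the compounds named here.

The three measured compounds share one core and differ in the group attached to it. Compound 1 `OCCNc1nnc2nncn2n1` carries a (2-hydroxyethyl)amino group and gives 11600 nM in a functional assay on MCF7 cells (Homo sapiens) for inhibition, read by MTT assay, with a stated time of 72 h (on this read-out higher numbers stand for weaker inhibition and lower numbers for stronger inhibition), the highest of the three numbers. Compound 2 `c1nnc2nnc(N3CCCC3)nn12` gives 5130 nM in this assay, and compound 3 `CCCCCC(=O)N1CCN(c2nnc3nncn3n2)CC1` gives 5260 nM; each of those two values lies beyond the usual scatter below the value of compound 1, while compounds 2 and 3 themselves are within the scatter of each other.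

Compound 4 `CCCNc1nnc2nncn2n1` has not yet been measured. It differs from compound 1 in one place: methyl in place of hydroxy on a saturated chain carbon, two bonds along the chain from a nitrogen on an aromatic ring. Within the data shown here, no measured pair in this set shows exactly this change, so its size can only be judged from the neighbours. Compounds 2 and 3, which carry no hydroxy, both sit lower than compound 1, but each differs from compound 1 in more than this one group, so they give only a loose hint.

On that basis a small step toward lower numbers is expected for compound 4, of a size a 1.5-fold lower number from compound 1 to compound 4 (0.16 log units; within the scatter) that may not clear the scatter. Compound 4 is therefore estimated at 8000 nM in this assay, within a range from 3000 nM to 20000 nM.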

Compound 4, half-maximal inhibitory concentration: 19800 nM
For compound 4 the middle estimate is 2.5-fold (0.39 log units) below the measured one, within the range that was stated.
By their numbers in this assay, from the lowest: compounds 2 and 3 (each within the scatter of the next); then compounds 1 and 4 (each within the scatter of the next).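

In this assay, the exchange of hydroxy for methyl on a saturated chain carbon, two bonds along the chain from a nitrogen on an aromatic ring, gives a 1.7-fold higher number from compound 1 to compound 4 (0.23 log units; within the scatter) and thus provides a direct reading of this change. The earlier compounds shown here could not give this reading. They differ in more than this one group. The change from (2-hydroxyethyl)amino to propylamino removes a hydrogen-bond donor and a hydrogen-bond acceptor, yet the two compounds cannot be told apart on this read-out, so in this single pair the hydroxy shows no effect that clears the scatter. Nothing available explains why this exchange leaves the two numbers so close.

As far as these compounds go, what remains open is how other groups would read at the same chain carbon, such as an amine, a carboxylic acid or a methoxy group, and whether a longer chain such as butyl would stay equally close. One pair on one cell line also leaves open whether the same exchange would read alike on a different group attached to the shared core.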